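Removing the nitrile-bearing aryl from the sulfonyl group

The compounds below may be only part of what the source reports. "The series", "measured", "known", "first", "only" and "open" are said of these compounds alone.

Compound 1 `Cc1ccc2ncc(S(=O)(=O)c3cccc(C#N)c3)c(N3CCC(C)CC3)c2c1` stands second highest of the three numbers in an assay on isolated protein for displacement of a labelled ligand from metabotropic glutamate receptor 5 (Homo sapiens), with a stated time of 60 min, tested at 1 uM (a higher number here means more inhibition at the concentration tested (going by the name of the read-out), a lower number less inhibition), where compound 1 gives 52%. Compound 2 `COc1ccc2ncc(S(=O)(=O)c3cccc(C#N)c3)c(N3CCC(C)CC3)c2c1` gives 90% and compound 3 `COc1ccc2ncc(S(=O)(=O)c3ccc(F)cc3)c(N3CCC(C)CC3)c2c1` gives 27%; the step of a number 38 percentage points higher from compound 1 to compound 2 (beyond the scatter) is large, and so is a number 63 percentage points lower from compound 2 to compound 3 (beyond the scatter). Compound 4 `Cc1ccc2ncc(S(=O)(=O)c3ccc(C)c(F)c3)c(N3CCC(C)CC3)c2c1` differs from compound 1 by 3-fluoro-4-methylphenyl in place of 3-cyanophenyl on a sulfonyl sulfur. Of the measured steps only a number 63 percentage points lower from compound 2 to compound 3 (beyond the scatter) bears on this change: that step likewise removes the 3-cyanophenyl from the sulfonyl sulfur and brings in a fluorine-bearing ring, and it was large and downward. Among the compounds with values here, a downward step beyond the scatter is therefore expected, a number 32 percentage points lower from compound 1 to compound 4 (beyond the scatter), with some caution since the entering ring is not the one seen in compound 3. Compound 4 is estimated at 20%, within a range from 5% to 45%.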

Compound 4, a percentage reported as inhibition, at one concentration (the size of the read-out at that concentration, not a potency): 91%
For compound 4 the middle estimate is 71 percentage points below the measured one; the measured number lies above the stated range.
By their numbers in this assay, from the lowest: compound 3; then compound 1; then compounds 2 and 4 (each within the scatter of the next).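

In this assay, the 3-cyanophenyl on the sulfonyl sulfur can be replaced without loss, with 3-fluoro-4-methylphenyl giving a number 39 percentage points higher from compound 1 to compound 4 (beyond the scatter). The nitrile is therefore not required at this place, and the direction of the change depends on the entering ring or the core, as a number 63 percentage points lower from compound 2 to compound 3 (beyond the scatter) runs the other way. No measurement at hand explains this difference.

Open, on these data alone, is whether the fluorine or the methyl of the entering ring accounts for the step, and how 3-fluoro-4-methylphenyl reads on the methoxy core of compound 2. Also open, as far as these compounds go, is how an amine or a carboxylic acid on this ring would read.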